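The source may report more compounds than this note shows. Statements on the series, on what has been measured and on what is new or still open speak of the compounds shown alone.

The study covers three hydrazone analogues that share one core and differ only in their substituents. Compound 1 `COc1cc(/C=C/C=N/NC(=O)c2ccc(C(C)(C)C)cc2)ccc1O` carries a hydroxy on one ring, and in a physicochemical assay, read by spectrophotometry, with a stated time of 60 min, tested at 100 uM (on this read-out lower numbers stand for a weaker effect and higher numbers for a stronger effect at the one concentration tested), compound 1 gives 45.6%. Compound 2 `COc1ccc(/C=C/C=N/NC(=O)c2ccc(C(C)(C)C)cc2)cc1` lacks that hydroxy, and in this assay compound 2 gives 8.3%, the lowest of the two numbers shown, with its nearest neighbour, compound 1, standing higher by a margin beyond the scatter. Compound 3 `COc1ccc(/C=C/C=N/NC(=O)c2ccc(O)cc2)cc1` has not yet been measured. It differs from compound 2 in one place: hydroxy in place of tert-butyl on an aromatic carbon.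

Among the compounds with values here, no step between measured compounds is recorded, so any expectation must rest on the two values above. Since compound 1 with a hydroxy gives 45.6% while compound 2 without one gives 8.3%, the account expects that bringing in a hydroxy will raise the read-out, by an estimated step from compound 2 to compound 3 of a number 26.7 percentage points higher from compound 2 to compound 3 (beyond the scatter), larger than the scatter. For compound 3 the estimated value in this assay is therefore 35%, within a range from 10% to 65%.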

Compound 3, a percentage reported as inhibition, at one concentration (the size of the read-out at that concentration, not a potency): 1.5%
Compound 3: middle estimate off by 33.5 percentage points, on the high side, and the stated range ends above it.
By their numbers in this assay, from the lowest: compounds 3 and 2 (each within the scatter of the next); then compound 1.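

Exchanging tert-butyl for hydroxy on an aromatic carbon, para to a large group, gives in this assay a step of a number 6.8 percentage points lower from compound 2 to compound 3 (within the scatter), so this exchange leaves the read-out of compound 2 and compound 3 within the usual scatter of each other. The clear gain seen when compound 1 carries its hydroxy therefore does not appear with a hydroxy at this position, which lies on a different ring of the shared core, and the presence of a hydroxy alone does not account for a strong read-out across these compounds. The result also shows that tert-butyl can leave this position without a change beyond the scatter, even though hydroxy differs from it in size and in its hydrogen-bond donor and acceptor counts. Nothing available explains why the hydroxy counts at one position and not at the other.

The compounds shown leave open whether an amine, a carboxylic acid or a longer chain on this aromatic carbon would move the read-out beyond the scatter. They also leave open whether the exchange of tert-butyl for hydroxy would give a similar step in the core of compound 1, where the first hydroxy is present.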